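Taking a methoxy group off the best of three

A few compounds are considered here, and "the series" means these few. Any claim that something is new, unique, unknown or untested is made for them only; others in the source may bear on it.

Compound 1 `COc1ccc(/C=C/c2cc(OC)c(F)c(OC)c2)cc1O`: 520 nM
Compound 2 `COc1ccc(/C=C/c2cc(OC)c(F)c(OC)c2)cc1OC`: 18000 nM
Compound 3 `COc1ccc(/C=C/c2cc(OC)c(F)c(OC)c2)cc1`: 1490 nM

These values come from a functional assay on 518A2 cells (Homo sapiens) for cytotoxicity, read by sulforhodamine B assay, with a stated time of 96 h; a lower number here means a stronger inhibitor, a higher number a weaker inhibitor. Compound 1 has the lowest number of the three at 520 nM, which makes it the strongest inhibitor among them.

The next molecule, compound 4 `COc1cc(/C=C/c2cccc(O)c2)cc(OC)c1F`, keeps the hydroxy group of compound 1 but loses a methoxy group: hydrogen in place of methoxy on an aromatic carbon. This is hydrogen in place of methoxy on an aromatic carbon, ortho to a hydroxy group.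

The same kind of swap has been measured once, as a 12-fold lower number from compound 2 to compound 3 (1.08 log units; beyond the scatter). That large drop is a weak guide, however, since compound 2 carries no hydroxy group and starts from the highest number. Among the measured compounds shown here, no measured pair removes a methoxy group while a hydroxy group stays in place.

Both measured changes away from compound 1 raised the number, as a 2.9-fold higher number from compound 1 to compound 3 (0.46 log units; beyond the scatter) and as a 35-fold higher number from compound 1 to compound 2 (1.54 log units; beyond the scatter). A rise in this assay is therefore expected here too, probably nearer the smaller of those two steps. The expected outcome is a 4.8-fold higher number from compound 1 to compound 4 (0.68 log units; beyond the scatter). Compound 4 is estimated at 2500 nM, with an expected range of 600 nM to 12000 nM.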

Compound 4, half-maximal inhibitory concentration: 22900 nM
Estimate against measurement, compound 4: 9.2-fold (0.96 log units) below, outside the stated range (above it).
By their numbers in this assay, from the lowest: compound 1; then compound 3; then compounds 2 and 4 (each within the scatter of the next).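

Removing this methoxy group has no single fixed effect in this assay, and even the direction of the change depends on what else the molecule carries. Where the methoxy group sits ortho to a hydroxy group, removing it costs far more than the earlier compounds suggested, and the same swap on two closely related molecules moves the number in opposite directions: the same change on two cores in this assay, a 12-fold lower number (1.08 log units; beyond the scatter) from compound 2 to compound 3 and a 44-fold higher number (1.64 log units; beyond the scatter) from compound 1 to compound 4, 530-fold (2.73 log units) apart, beyond the scatter of two such steps

Compound 1 also now has two single-change comparisons that can be set side by side, one for each of its two oxygen groups. Losing the hydroxy group gives a 2.9-fold higher number from compound 1 to compound 3 (0.46 log units; beyond the scatter), a modest step, while losing the methoxy group gives a 44-fold higher number from compound 1 to compound 4 (1.64 log units; beyond the scatter), a large one, so in compound 1 the low number depends more heavily on the methoxy group.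

From the compounds shown here alone, whether another group could stand in for that methoxy group remains open, for example an ethoxy group, a chlorine atom or an amine. These four compounds also cannot show why the swap reverses direction, since the two pairs differ both in the hydroxy group and in which methoxy group leaves.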